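The source may report more compounds than this note shows. Statements on the series, on what has been measured and on what is new or still open speak of the compounds shown alone.

Two cores are in play. Compound 1 `CC(C)C[C@H](N)c1cc(C(F)(F)F)ccc1N1CCN(C(=O)[C@H]2CSC[C@@H]2c2ccc(Cl)cc2)CC1` and compound 2 `CC(C)C[C@H](N)c1cc(C(F)(F)F)ccc1N1CCN(C(=O)C2C(=O)OCC2c2ccc(Cl)cc2)CC1` carry the same amine-bearing side; the difference between the two cores is not broken down here. In an assay on HEK293 cells for displacement of a labelled ligand from Melanocortin receptor 4 (Homo sapiens) (on this read-out higher numbers stand for weaker inhibition and lower numbers for stronger inhibition), compound 1 gives 280 nM and compound 2 gives 260 nM, values that sit within the usual scatter of each other.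

Compound 3 `CC(C)C[C@H](NC(=O)CCN(C)C)c1cc(C(F)(F)F)ccc1N1CCN(C(=O)[C@H]2CSC[C@@H]2c2ccc(Cl)cc2)CC1` is compound 1 with one change: (2-(dimethylamino)ethyl)carbonyl in place of hydrogen on an amine nitrogen. In this assay compound 3 gives 130 nM, which makes a 2.2-fold lower number from compound 1 to compound 3 (0.33 log units; beyond the scatter).

Compound 4 `CC(C)C[C@H](NC(=O)CCN(C)C)c1cc(C(F)(F)F)ccc1N1CCN(C(=O)C2C(=O)OCC2c2ccc(Cl)cc2)CC1` is not yet measured. It carries the same change on the core of compound 2: (2-(dimethylamino)ethyl)carbonyl in place of hydrogen on an amine nitrogen. The change occurs twice among these compounds, once measured. The step expected from compound 2 to compound 4 in this assay is a 2.2-fold lower number from compound 2 to compound 4 (0.34 log units; beyond the scatter). That expectation rests on a single instance, the step from compound 1 to compound 3 of a 2.2-fold lower number from compound 1 to compound 3 (0.33 log units; beyond the scatter), and on the two starting points of compound 1 at 280 nM and compound 2 at 260 nM lying close together. Compound 4 is therefore expected to give 120 nM in this assay. For compound 4 the expected range runs from 60 nM to 260 nM.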

Compound 4, inhibition constant: 290 nM
Beside the measured number, compound 4's estimate is 2.4-fold (0.38 log units) below it; measured number outside the range, above it.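

On the other core, in this assay, the same change gives a 1.1-fold higher number from compound 2 to compound 4 (0.05 log units; within the scatter), so the step beyond the scatter seen on the core of compound 1 has no counterpart beyond the scatter here. Set side by side, the two steps still cannot be told apart: the same change on two cores in this assay, a 2.2-fold lower number (0.33 log units; beyond the scatter) from compound 1 to compound 3 and a 1.1-fold higher number (0.05 log units; within the scatter) from compound 2 to compound 4, 2.4-fold (0.38 log units) apart, within the scatter of two such steps. Among the compounds shown here, the pair therefore shows no firm dependence on the core, but it also gives no support for counting on a gain from (2-(dimethylamino)ethyl)carbonyl on a new core, since each core offers only a single step and the size of the effect is close to the scatter.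

Open, as far as these compounds go, is whether a plain acetyl on the same amine nitrogen would give steps like these, which would indicate how much depends on the terminal dimethylamino group. Also open, from the compounds shown here alone, is whether a longer chain ending in that amine, or a carboxylic acid in its place, would separate the two cores.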